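Series notes: substituent on the benzyl ring, compound 4

The source may report more compounds than this note shows. Statements on the series, on what has been measured and on what is new or still open speak of the compounds shown alone.

Three compounds share one core and differ only in the aryl group bound to the saturated chain carbon next to the amine nitrogen. In a functional assay on HT-29 cells (Homo sapiens) for inhibition, read by MTT assay, with a stated time of 72 h (on this read-out lower numbers stand for stronger inhibition of growth and higher numbers for weaker inhibition of growth), compound 1 `COc1ccc(CNCCCNS(=O)(=O)c2cc(C(F)(F)F)cc(C(F)(F)F)c2)cc1OC` gives 2700 nM, compound 2 `O=S(=O)(NCCCNCc1ccc(C(F)(F)F)cc1)c1cc(C(F)(F)F)cc(C(F)(F)F)c1` gives 2900 nM, and compound 3 `O=S(=O)(NCCCNCc1ccccc1)c1cc(C(F)(F)F)cc(C(F)(F)F)c1` gives 15000 nM. Compound 3 has the highest number of the three; the steps of a 5.6-fold higher number from compound 1 to compound 3 (0.74 log units; beyond the scatter) and a 5.2-fold higher number from compound 2 to compound 3 (0.71 log units; beyond the scatter) are both beyond the scatter, while a 1.1-fold higher number from compound 1 to compound 2 (0.03 log units; within the scatter) is within it.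

Compound 4 `O=S(=O)(NCCCNCc1ccc(-c2ccccc2)cc1)c1cc(C(F)(F)F)cc(C(F)(F)F)c1` is reached from compound 3 by phenyl in place of hydrogen on an aromatic carbon. For the measured compounds named here, the steps that bear on this are the two into compound 3: removing a group from the benzyl ring, whether trifluoromethyl or the two methoxy groups, raised the number by a modest amount each time. Putting a group back at the same position, here phenyl, is therefore expected to lower the number in this assay by a step of similar size, and compound 4 is expected to show a 5.0-fold lower number from compound 3 to compound 4 (0.70 log units; beyond the scatter). Compound 4 is thus estimated at 3000 nM, within the range 1000 nM to 10000 nM.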

Compound 4, concentration for 50% growth inhibition: 2300 nM
For compound 4 the middle estimate is 1.3-fold (0.12 log units) above the measured one; measured number inside the range.
By their numbers in this assay, from the lowest: compounds 4, 1 and 2 (each within the scatter of the next); then compound 3.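

Working notes: in this assay, a substituent at this position lowers the number even when it is a whole six-membered aromatic ring of carbon only, with a 6.5-fold lower number from compound 3 to compound 4 (0.81 log units; beyond the scatter), a step of about the same size as those seen with the smaller groups on the benzyl ring. Exchanging trifluoromethyl for phenyl at the same place gives a 1.3-fold lower number from compound 2 to compound 4 (0.10 log units; within the scatter), so this assay does not separate the two groups, and the larger group of 6 heavy atoms costs nothing measurable here. No measurement at hand accounts for either step.

Still open, going by these compounds, is whether a carboxylic acid or an amine in place of the phenyl of compound 4 would hold the number or lose the step. Also open, on these data alone, is whether the phenyl step would persist with a longer chain between the two nitrogens of the core.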